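Pyridine Swap and Expected Cell Tolerance

The source may report more compounds than this note shows. Statements on the series, on what has been measured and on what is new or still open speak of the compounds shown alone.

Compound 2 `Cc1nc(NCCNS(C)(=O)=O)nc(N[C@@H]2C[C@H](CO)[C@@H](O)[C@H]2O)c1-c1nc2ccccc2s1` was tested in an ADME assay on cells (Homo sapiens) for cytotoxicity, read by polymerase chain reaction, with a stated time of 3 days; a higher number here means that more compound is tolerated, a lower number that less compound is tolerated. There compound 2 gives > 25000 nM, which is a limit of the assay rather than a number. Compound 1 `Nc1nc(Cl)c(-c2cc3ccccc3s2)c(N[C@@H]2C[C@H](CO)[C@@H](O)[C@H]2O)n1` was tested as well. In this assay compound 1 gives > 25000 nM, again a limit. Both sit together, as shown by the limit of > 25000 nM in this assay, at which 2 of the 2 values shown sit. Compound 3 `Cc1nc(NCc2ccncc2)nc(N[C@@H]2C[C@H](CO)[C@@H](O)[C@H]2O)c1-c1nc2ccccc2s1` has not yet been measured; it differs from compound 2 by pyridin-4-yl in place of (methanesulfonamido)methyl on a saturated chain carbon bound to a nitrogen on an aromatic ring. Going by the values given here, no step between measured compounds is known, so no change beyond the scatter is expected in either direction. For compound 3 the expected value in this assay is 25000 nM, between 10000 nM and 60000 nM. The expected step is a number no higher from compound 2 to compound 3 (the limit leaves the size open).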

Compound 3, half-maximal cytotoxic concentration: 7000 nM
For compound 3 the middle estimate is 3.6-fold (0.55 log units) above the measured one, outside the stated range (below it).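

In this assay, the place on a saturated chain carbon bound to a nitrogen on an aromatic ring turns out to matter: pyridin-4-yl in place of (methanesulfonamido)methyl gives an at least 3.5-fold lower number from compound 2 to compound 3 (0.55 log units; beyond the scatter). Going by these compounds alone, compound 3 is the first compound here with a number rather than a limit. The full size of the step stays unknown because compound 2 sits at a limit: the limit of > 25000 nM in this assay, at which 2 of the 3 values shown sit.

On these data alone, whether the entering pyridine ring or the loss of the methanesulfonamido group matters more remains open. A phenyl ring or a carboxylic acid at this place could separate the two.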